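Aryl change on the enone chain of the thioether series

The source may hold more compounds than are shown below. What is called first, only, known or untested is meant among the compounds shown, and "the series" means these compounds.

Compound 1 `CN(C)c1ccc(/C=C(/SCc2ccc(Cl)cc2Cl)C(=O)c2ccc(Cl)cc2)cc1` — 50000 nM
Compound 2 `Cc1ccc(CS/C(=C/c2ccc(C)s2)C(=O)c2ccc(Cl)cc2)cc1` — 50000 nM
Compound 3 `Cc1ccc(CS/C(=C/c2ccc(N(C)C)cc2)C(=O)c2ccc(Cl)cc2)cc1` — a limit only, > 100000 nM

In a functional assay on DU-145 cells (Homo sapiens) for inhibition, read by trypan blue exclusion, with a stated time of 96 h (on this read-out lower numbers stand for stronger inhibition of growth and higher numbers for weaker inhibition of growth), compound 1 gives 50000 nM and compound 2 gives 50000 nM. For compound 3 the read-out is a limit, > 100000 nM, the bound recorded as the limit of > 100000 nM in this assay, at which 1 of the 3 values shown sits; compound 3 thus stands with no number of its own. The steps of an at least 2.0-fold higher number from compound 1 to compound 3 (0.30 log units; that floor lies within the scatter) and an at least 2.0-fold higher number from compound 2 to compound 3 (0.30 log units; that floor lies within the scatter) both end at that limit, and each is only a floor within the scatter. Compound 4 `Cc1ccc(CS/C(=C/c2c[nH]c3ccc(Cl)cc23)C(=O)c2ccc(Cl)cc2)cc1` differs from compound 3 by 5-chloro-1H-indol-3-yl in place of 4-(dimethylamino)phenyl on a double-bonded chain carbon bound to a double-bonded chain carbon. For the measured compounds named here, only the step of an at least 2.0-fold higher number from compound 2 to compound 3 (0.30 log units; that floor lies within the scatter) concerns the same place, and it fixes no size. The step is expected to be an at least 2.0-fold lower number from compound 3 to compound 4 (0.30 log units; that floor lies within the scatter). Compound 4 is estimated at 50000 nM, with a range from 10000 nM to 100000 nM.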

Compound 4, concentration for 50% growth inhibition: 1000 nM
The estimate for compound 4 lay 50-fold (1.70 log units) above the measured number; the measured number lies below the stated range.
By their numbers in this assay, from the lowest: compound 4; then compounds 1 and 2 (each within the scatter of the next). At a limit, above all of these: compound 3.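

At the double-bonded chain carbon, the change to 5-chloro-1H-indol-3-yl gives steps of measurable consequence: an at least 100-fold lower number from compound 3 to compound 4 (2.00 log units; beyond the scatter) and a 50-fold lower number from compound 2 to compound 4 (1.70 log units; beyond the scatter). The earlier steps shown here at this place fixed no size, whereas the step from the 5-methylthiophen-2-yl compound now gives one beyond the scatter. The step from compound 3 remains a floor, as compound 3 holds only a limit: the limit of > 100000 nM in this assay, at which 1 of the 4 values shown sits.

Open, as far as these compounds go, is how a 1H-indol-3-yl without the chlorine, or with an amine in its place, would read at this position. Also open, from the compounds shown here alone, is whether the step holds with 2,4-dichlorophenyl on the saturated chain carbon bound to a sulfur.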